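A few compounds are considered here, and "the series" means these few. Any claim that something is new, unique, unknown or untested is made for them only; others in the source may bear on it.

The series shares the core seen in compound 1 `Cn1nnnc1SCC(=O)N/N=C/c1ccc(F)cc1`, compound 2 `Cn1nnnc1SCC(=O)N/N=C/c1ccc(O)cc1` and compound 3 `Cn1nnnc1SCC(=O)N/N=C/c1ccccc1[N+](=O)[O-]`, with variation on the six-membered aromatic ring of carbon only. In an ADME assay on NIH3T3 cells (Mus musculus) for cytotoxicity, read by XTT assay, with a stated time of 24 h (a lower number here means a stronger inhibitor, a higher number a weaker inhibitor), compound 1 gives 10000000 nM. In this assay, among the compounds with values here, compound 2 gives 632000 nM, and the step of a 16-fold lower number from compound 1 to compound 2 (1.20 log units; beyond the scatter) is the only single-point step among the measured compounds. In this assay compound 3 gives 2020000 nM. Compound 3 stands second highest of the three numbers, with compound 2 the nearest and compound 1 the furthest.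

Compound 4 `COc1ccccc1/C=N/NC(=O)CSc1nnnn1C` differs from compound 3 by methoxy in place of nitro on an aromatic carbon. Within the data shown here, no measured step concerns a nitro or a methoxy, and the hydroxy-for-fluoro step a 16-fold lower number from compound 1 to compound 2 (1.20 log units; beyond the scatter) involves other groups, so it offers no direct guide. With nothing else to go on, no step beyond the scatter is expected in this assay. The step expected in this assay is a 1.0-fold lower number from compound 3 to compound 4 (0.00 log units; within the scatter). Compound 4 is therefore expected to give about 2000000 nM in this assay, within a wide range from 500000 nM to 8000000 nM.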

Compound 4, half-maximal inhibitory concentration: 3160000 nM
Compound 4: middle estimate off by 1.6-fold (0.20 log units), on the low side, and the stated range covers the measured number.
By their numbers in this assay, from the lowest: compound 2; then compounds 3 and 4 (each within the scatter of the next); then compound 1.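

At this place, an aromatic carbon ortho to a large group, methoxy in place of nitro gives a 1.6-fold higher number from compound 3 to compound 4 (0.19 log units; within the scatter) in this assay and so this read-out does not separate the two groups here. Within the data shown here, the only other step, a 16-fold lower number from compound 1 to compound 2 (1.20 log units; beyond the scatter), lies beyond the scatter and involves neither group, so the two steps together show that a change on the aromatic ring need not move the number beyond the scatter. Nothing at hand explains why nitro and methoxy read alike at this place.

From the compounds shown here alone, whether an amine, a carboxylic acid or a longer chain such as butoxy at this place would also stay within the scatter of compound 3 remains open. Among these compounds, also open is whether fluoro or hydroxy at this place would give a step like the one between compound 1 and compound 2.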